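The source may hold more compounds than are shown below. What is called first, only, known or untested is meant among the compounds shown, and "the series" means these compounds.

Measured compounds:
- compound 1, `Nc1cc(N)c2nc(-c3ccccc3)c(NCc3ccc(Cl)c(Cl)c3)nc2c1`: < 100000 nM
- compound 2, `COc1ccc(CNc2nc3cc(N)cc(N)c3nc2-c2ccccc2)cc1OC`: < 100000 nM
- compound 3, `Nc1cc(N)c2nc(-c3ccccc3)c(NCc3ccc(F)cc3)nc2c1`: 60300 nM

In a functional assay on RXF 393 cells (Homo sapiens) for inhibition, read by sulforhodamine B assay, with a stated time of 48 h (on this read-out higher numbers stand for lower toxicity in this test and lower numbers for higher toxicity in this test), compound 1 gives < 100000 nM, which is a limit of the assay and not a number. Compound 2 likewise gives < 100000 nM, again a limit. Going by the values given here, compound 3 gives 60300 nM, the only number among the three values shown, so compound 3 is the single fixed point of the series. The change from compound 1 to compound 2 reads a step that the two limits leave unreadable from compound 1 to compound 2, from compound 1 to compound 3 a step that the limit leaves unreadable from compound 1 to compound 3, and from compound 2 to compound 3 a step that the limit leaves unreadable from compound 2 to compound 3; none of these has a readable size because of the limit of < 100000 nM in this assay, at which 2 of the 3 values shown sit.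

Compound 4 is `COc1ccc(CNc2nc3cc(N)cc(N)c3nc2-c2ccccc2)cc1`, not yet measured. It differs from compound 3 by methoxy in place of fluoro on an aromatic carbon. The measured steps that touch the benzyl substituent give no size to go on, and nothing among them points in either direction. The expectation is therefore a step from compound 3 to compound 4 of a 1.0-fold lower number from compound 3 to compound 4 (0.00 log units; within the scatter) in this assay, that is, none beyond the usual scatter, with a real chance that only a limit is reported. Compound 4 is estimated at 60000 nM, with a range from 25000 nM to 150000 nM.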

Compound 4, concentration lethal to 50% of the cells: 44700 nM
The estimate for compound 4 lay 1.3-fold (0.13 log units) above the measured number; measured number inside the range.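

In this assay the series now has its first readable step, a 1.3-fold lower number from compound 3 to compound 4 (0.13 log units; within the scatter), for methoxy in place of fluoro on an aromatic carbon, para to a large group. At this position the two groups are therefore not told apart in this test, even though the change swaps 1 heavy atom and no hydrogen-bond acceptor for 2 heavy atoms and 1 hydrogen-bond acceptor. The steps that link compound 1 and compound 2 to compound 4 cannot be read, because each of them ends on a value that is a limit of the assay and not a number: the limit of < 100000 nM in this assay, at which 2 of the 4 values shown sit.

As far as these compounds go, whether the second ring substituent carried by compound 1 and compound 2 shifts the number therefore remains open, so the effect of 3,4-disubstitution on the phenyl ring cannot be separated from that of 4-substitution alone. Going by these compounds alone, also open is whether the absence of a readable step extends beyond fluoro and methoxy at this carbon, for example to an amine, a carboxylic acid or a longer alkoxy chain, since the two readable values cover only this one pair of groups.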